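The compounds below may be only part of what the source reports. "The series", "measured", "known", "first", "only" and "open" are said of these compounds alone.

Working notes on the series. Compound 2 `Nc1cccc(CCCCCCC(=O)c2ncc(-c3ccccn3)o2)c1` is measured in an assay for inhibition of Fatty-acid amide hydrolase 1 (Rattus norvegicus) (on this read-out lower numbers stand for stronger inhibition and higher numbers for weaker inhibition), where compound 2 gives 30 nM. For the measured compounds named here, this is the highest of the two numbers so far; the only neighbour is compound 1 `O=C(CCCCCCc1ccccc1Cl)c1ncc(-c2ccccn2)o1`, which in this assay gives 1.9 nM, and the one measured step, a 16-fold higher number from compound 1 to compound 2 (1.20 log units; beyond the scatter), runs from there to compound 2.

Compound 3 `O=C(CCCCCSc1ccccc1)c1ncc(-c2ccccn2)o1` is not yet measured. Its change from compound 2 is phenylsulfanyl in place of 3-aminobenzyl on a saturated chain carbon, five bonds along the chain from a carbonyl carbon. Going by the values given here, no measured pair shows exactly this exchange; the step of a 16-fold higher number from compound 1 to compound 2 (1.20 log units; beyond the scatter) bears on it only insofar as it shows that the aryl end of the chain can move the number a great deal, and that the 3-amino group goes with the higher number. Compound 3 carries no such group, so a return toward the number of compound 1 is the working expectation, tempered for the shorter chain and the sulfur. Compound 3 is therefore expected at 6 nM, within 1.5 nM to 25 nM, a step of a 5.0-fold lower number from compound 2 to compound 3 (0.70 log units; beyond the scatter).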

Compound 3, inhibition constant: 3 nM
For compound 3 the middle estimate is 2.0-fold (0.30 log units) above the measured one; measured number inside the range.
By their numbers in this assay, from the lowest: compounds 1 and 3 (each within the scatter of the next); then compound 2.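

In this assay, phenylsulfanyl in place of 3-aminobenzyl gives a 10-fold lower number from compound 2 to compound 3 (1.00 log units; beyond the scatter), so a low number at this place does not depend on the 2-chlorobenzyl group of compound 1. Phenylsulfanyl in place of 2-chlorobenzyl gives a 1.6-fold higher number from compound 1 to compound 3 (0.20 log units; within the scatter), within the scatter, which shows that this end of the chain can carry an unsubstituted phenyl ring attached through sulfur and keep a number level with that of compound 1. Nothing available accounts for the size of either step.

From the compounds shown here alone, each exchange alters the sulfur, the chain length and the ring substituent together, so their separate contributions stay open. Also open, going by these compounds, is whether an unsubstituted benzyl group, a longer chain ending in phenylsulfanyl or a carboxylic acid on the phenyl ring would hold the number at this level.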